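The source may report more compounds than this note shows. Statements on the series, on what has been measured and on what is new or still open speak of the compounds shown alone.

Measured so far in a functional assay on A549 cells (Homo sapiens) for cytotoxicity, read by MTT assay, with a stated time of 72 h (on this read-out higher numbers stand for weaker inhibition and lower numbers for stronger inhibition), and still open:
- compound 1 `CCc1ccc(-c2cc(C(=O)Nc3ccc(Oc4ccnc(C(=O)NC)c4)cc3)ncn2)cc1` gives 13300 nM
- compound 2 `CNC(=O)c1cc(Oc2ccc(NC(=O)c3cc(-c4ccc(F)cc4)ncn3)cc2)ccn1` gives > 100000 nM as a limit
- compound 3 `CNC(=O)c1cc(Oc2ccc(NC(=O)c3cc(-c4ccc(OC)cc4)ncn3)cc2)ccn1` is not yet measured

Compound 2 has only a limit and no number. Compound 3 differs from it by methoxy in place of fluoro on an aromatic carbon in the form of methoxy in place of fluoro on an aromatic carbon. Within the data shown here, one measured step bears on this carbon: an at least 7.5-fold higher number from compound 1 to compound 2 (0.87 log units; beyond the scatter) when fluoro replaced ethyl. Losing fluoro is therefore expected to lower the number, though the size stays open because of the limit of > 100000 nM in this assay, at which 1 of the 2 values shown sits, and no measured step involves methoxy. An estimated step of an at least 2.8-fold lower number from compound 2 to compound 3 (0.45 log units; beyond the scatter) is expected. The estimate for compound 3 is 35000 nM with an expected range of 10000 nM to 100000 nM in this read-out.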

Compound 3, half-maximal inhibitory concentration: 13500 nM
The estimate for compound 3 lay 2.6-fold (0.41 log units) above the measured number; low and high end bracket the measured number.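

On this aromatic carbon, para to a large group, the earlier drop with fluoro now reads as specific to fluoro rather than as a need for ethyl in this assay: methoxy gives an at least 7.4-fold lower number from compound 2 to compound 3 (0.86 log units; beyond the scatter), and the ethyl and methoxy compounds stand level, with a 1.0-fold higher number from compound 1 to compound 3 (0.01 log units; within the scatter). The true size of the fluoro penalty stays open because compound 2 has only a limit and no number: the limit of > 100000 nM in this assay, at which 1 of the 3 values shown sits.

On these data alone, whether an amine, a carboxylic acid or a longer chain on this carbon would hold the level of ethyl and methoxy stays open. So does whether any group here can bring the number clearly lower.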